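Coumarin-triazole lipoamide series: aryl for acetyl at the lactone ring

A few compounds are considered here, and "the series" means these few. Any claim that something is new, unique, unknown or untested is made for them only; others in the source may bear on it.

Measured compounds:
- compound 1, `CC(=O)c1cc2ccc(OCCCn3cc(CNC(=O)CCCCC4CCSS4)nn3)cc2oc1=O`: 38%
- compound 2, `O=C(CCCCC1CCSS1)NCc1cn(CCCOc2ccc3cc(C(=O)O)c(=O)oc3c2)nn1`: 59.9%

For the measured compounds named here, in a functional assay on PC-12 cells (Rattus norvegicus) for cytotoxicity, read by MTT assay, with stated times of 3 h and 2 h, tested at 10 uM (a lower number here means a weaker effect, a higher number a stronger effect of the compound at the concentration tested), compound 1 gives 38% and stands at the lower of the two numbers so far; compound 2 gives 59.9%. Going by the values given here, the one step recorded so far, a number 21.9 percentage points higher from compound 1 to compound 2 (beyond the scatter), swaps a group on the carbonyl carbon of the acetyl and leaves the rest of the shared core untouched.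

Compound 3, `O=C(CCCCC1CCSS1)NCc1cn(CCCOc2ccc3cc(-c4ccc(Cl)cc4)c(=O)oc3c2)nn1`, is not yet measured. It differs from compound 1 by 4-chlorophenyl in place of acetyl on an aromatic carbon. The acetyl is removed entirely and a six-membered aromatic ring of carbon only takes its place; the carbonyl that was modified in the step from compound 1 to compound 2 is no longer present. Among the compounds with values here, no measured step touches this kind of replacement, so the step from compound 1 to compound 2 bears on it only by showing that this position of the core can move the read-out by a modest amount when altered. Going by these compounds, the direction for an aryl ring is unknown from these data. A change of about the size of the earlier step, in either direction, is therefore expected, a number 7 percentage points higher from compound 1 to compound 3 (within the scatter), with no claim to its sign. Compound 3 is estimated at 45%, with a range from 22% to 68%.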

Compound 3, a percentage reported as activity, at one concentration (the size of the read-out at that concentration, not a potency): 67.8%
The estimate for compound 3 lay 22.8 percentage points below the measured number, and the stated range covers the measured number.
By their numbers in this assay, from the lowest: compound 1; then compounds 2 and 3 (each within the scatter of the next).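

In this assay, 4-chlorophenyl in place of acetyl on this aromatic carbon gives a number 29.8 percentage points higher from compound 1 to compound 3 (beyond the scatter), which fixes a direction the earlier pair could not give for an aryl ring and shows that a carbonyl on this carbon is not needed for the higher read-out. With 4-chlorophenyl in place of carboxy there is a number 7.9 percentage points higher from compound 2 to compound 3 (within the scatter), so these two quite different groups cannot be told apart in this read-out, and of the three groups only acetyl stands apart from the others, beyond the scatter. Nothing on hand explains why the read-out moves with the group at this position.

The compounds shown do not separate the contribution of the aryl ring from that of its chlorine, which an unsubstituted phenyl or a 4-methoxyphenyl on the same carbon would address. Also open, going by these compounds, is whether a basic group such as an amine at this carbon would stay with compound 3 or fall back towards compound 1, and each reading here is a size of effect at one concentration, not a potency.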